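Swapping 4-methylpiperazin-1-yl for methyl on the shared core

A few compounds are considered here, and "the series" means these few. Any claim that something is new, unique, unknown or untested is made for them only; others in the source may bear on it.

Measured in a functional assay on MDA-MB-231 cells (Homo sapiens) for inhibition, read by MTT assay, with a stated time of 72 h; on this read-out higher numbers stand for weaker inhibition and lower numbers for stronger inhibition:
compound 1 `Cc1ccc(-c2cc(C(=O)N3CCC4(CC3)CC(=O)c3nn(C(C)(C)C)cc3O4)c3ccccc3n2)cc1`: > 10000 nM (a limit)
compound 2 `CC(C)(C)n1cc2c(n1)C(=O)CC1(CCN(C(=O)c3cc(N4CCNCC4)nc4ccccc34)CC1)O2`: 4200 nM
compound 3 `CN1CCN(c2cc(C(=O)N3CCC4(CC3)CC(=O)c3nn(C(C)(C)C)cc3O4)c3ccccc3n2)CC1`: 8130 nM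

In this assay compound 3 reads 8130 nM and lies within the scatter of compound 2 at 4200 nM on the numbers shown. Those two differ only by the methyl on the amine nitrogen, and a 1.9-fold higher number from compound 2 to compound 3 (0.29 log units; within the scatter) is the whole of that step. Compound 1 sits at the limit of > 10000 nM in this assay, at which 1 of the 3 values shown sits, and that value is a limit.

Compound 4 `Cc1cc(C(=O)N2CCC3(CC2)CC(=O)c2nn(C(C)(C)C)cc2O3)c2ccccc2n1` differs from compound 3 by methyl in place of 4-methylpiperazin-1-yl on an aromatic carbon in which methyl takes the place of 4-methylpiperazin-1-yl on an aromatic carbon. Among the compounds with values here, no measured step puts methyl there. The closest evidence replaces 4-methylphenyl on that carbon: an at least 2.3-fold lower number from compound 1 to compound 2 (0.37 log units; beyond the scatter) goes beyond the scatter with piperazin-1-yl, while an at least 1.2-fold lower number from compound 1 to compound 3 (0.08 log units; that floor lies within the scatter) has a floor within the scatter with 4-methylpiperazin-1-yl. Like compound 4, compound 1 carries no 4-methylpiperazin-1-yl, and its > 10000 nM is a limit.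

Given the small size of an at least 1.2-fold lower number from compound 1 to compound 3 (0.08 log units; that floor lies within the scatter) for compound 3, a shift toward a higher number is expected, though not one beyond the scatter. The expected change is a 1.4-fold higher number from compound 3 to compound 4 (0.13 log units; within the scatter) on this estimate. For compound 4 the estimated value is 11000 nM with 4500 nM to 25000 nM as the expected range.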

Compound 4, half-maximal inhibitory concentration: 4860 nM
Beside the measured number, compound 4's estimate is 2.3-fold (0.35 log units) above it, and the stated range covers the measured number.
By their numbers in this assay, from the lowest: compounds 2, 4 and 3 (each within the scatter of the next). At a limit, above all of these: compound 1.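

Read in this assay the aromatic carbon next to the ring nitrogen now shows that a lone methyl, with no ring and no hydrogen-bond acceptors, stays within the scatter of both piperazine compounds (a 1.7-fold lower number from compound 3 to compound 4 (0.22 log units; within the scatter)) and (a 1.2-fold higher number from compound 2 to compound 4 (0.06 log units; within the scatter)). Neither 4-methylpiperazin-1-yl nor piperazin-1-yl is therefore needed at this carbon for a reading in this range, and the three compounds cannot be told apart by the group they carry there. Only 4-methylphenyl stands apart, with methyl in its place giving a step beyond the scatter (an at least 2.0-fold lower number from compound 1 to compound 4 (0.31 log units; beyond the scatter)), and that step rests on compound 1, whose value is a limit and not a number: (the limit of > 10000 nM in this assay, at which 1 of the 4 values shown sits).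

The compounds shown leave open whether a plain hydrogen, a methoxy group or an ethyl chain at this carbon would read like methyl, or whether any group there could bring the number well below these values. They also leave open whether an unsubstituted phenyl would stand apart as 4-methylphenyl does, and how far compound 1 really lies from the others.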